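Chain extension on the N-substituent of a 5-alpha-reductase inhibitor

The compounds below may be only part of what the source reports. "The series", "measured", "known", "first", "only" and "open" are said of these compounds alone.

Compound 1 `CCCCc1ccc(Cn2ccc3cc(/C(C)=C/C(=O)Nc4ccccc4OCCCC(=O)O)ccc32)cc1`: 100 nM
Compound 2 `CCCC(c1ccccc1)n1ccc2cc(/C(C)=C/C(=O)Nc3ccccc3OCCCC(=O)O)ccc21`: 9.1 nM

Of the compounds shown here, two sharing the same core have been measured in an assay on Prostate gland for inhibition of steroid 5-alpha-reductase (Rattus norvegicus); a lower number here means a stronger inhibitor, a higher number a weaker inhibitor. Compound 1 carries a 4-butylbenzyl group on the aromatic nitrogen and gives 100 nM in this assay. Compound 2 replaces that group with 1-phenylbutyl and gives 9.1 nM. Going by the values given here, the single measured step, an 11-fold lower number from compound 1 to compound 2 (1.04 log units; beyond the scatter), is the only comparison available, and it leaves compound 2 with the lowest number of the two.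

Compound 3 `CCCCC(c1ccccc1)n1ccc2cc(/C(C)=C/C(=O)Nc3ccccc3OCCCC(=O)O)ccc21` is not yet measured. It differs from compound 2 by methyl in place of hydrogen on a saturated chain carbon, four bonds along the chain from an aromatic carbon and an aromatic nitrogen, which is to say the 1-phenylbutyl group becomes a 1-phenylpentyl group. The measured step from compound 1 to compound 2 bears on this only loosely, since it swapped a benzyl-type group for a branched phenylalkyl group rather than lengthening a chain. With no measured chain-length comparison in this series, the expected change in this assay for compound 3 is none beyond the scatter, expressed as a 1.1-fold lower number from compound 2 to compound 3 (0.06 log units; within the scatter). Compound 3 is therefore estimated at 8 nM, within a range of 3 nM to 25 nM.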

Compound 3, half-maximal inhibitory concentration: 9.8 nM
Compound 3: middle estimate off by 1.2-fold (0.09 log units), on the low side, and the stated range covers the measured number.
By their numbers in this assay, from the lowest: compounds 2 and 3 (each within the scatter of the next); then compound 1.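

In this assay, going by these compounds alone, the only comparison of chain length at this position gives a 1.1-fold higher number from compound 2 to compound 3 (0.03 log units; within the scatter) and so does not separate the 1-phenylbutyl and 1-phenylpentyl groups on the aromatic nitrogen. Methyl in place of hydrogen on this saturated chain carbon, four bonds along the chain from an aromatic carbon and an aromatic nitrogen, therefore leaves the reading in this assay where it was. The large gap to the 4-butylbenzyl compound also holds for the longer group, with a 10-fold lower number from compound 1 to compound 3 (1.01 log units; beyond the scatter) on record, and no evidence is available that bears on why the two chains read alike.

The compounds shown leave open whether a longer chain such as hexyl or octyl, or a butyl chain ending in an amine or a hydroxyl group, would still read like these two, and so how far this position accepts added atoms. They also leave open whether a substituent on the phenyl ring of the 1-phenylbutyl group, such as a fluorine atom or a methoxy group, would keep the reading of compound 2.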